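A Swapped Group on a Saturated Ring Carbon

A few compounds are considered here, and "the series" means these few. Any claim that something is new, unique, unknown or untested is made for them only; others in the source may bear on it.

Measured in a functional assay for inhibition, with Sus scrofa as the target; on this read-out higher numbers stand for weaker inhibition and lower numbers for stronger inhibition:
compound 1 `CC1(C)Oc2ccc(C#N)cc2[C@@H](Nn2ccccc2=O)[C@]1(C)O`: > 100000 nM (a limit)
compound 2 `CCn1nc(O[C@@H]2c3cc(C#N)ccc3OC(C)(C)[C@@]2(C)O)ccc1=O`: 7 nM

Compound 1 sits on (the limit of > 100000 nM in this assay, at which 1 of the 2 values shown sits). Compound 2, at 7 nM, shows that strong inhibition can be read in this assay. Among the measured compounds shown here, no step in a single place joins these two compounds, so they give no direct measure of any one change.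

Compound 3 `CC1(C)Oc2ccc(C#N)cc2[C@@H](n2nc(N)ccc2=O)[C@]1(C)O` keeps the core of compound 1 and changes one group, on a saturated ring carbon, next to the ring atom that bears a hydroxy group: a group of 8 heavy atoms (4 carbon, 3 nitrogen, 1 oxygen; one six-membered aromatic ring with 2 hetero atoms) in place of a group of 8 heavy atoms (5 carbon, 2 nitrogen, 1 oxygen; one six-membered aromatic ring with 1 hetero atom), on a saturated ring carbon. The new group carries one six-membered aromatic ring with 2 hetero atoms. A move toward stronger inhibition is expected, though its size is very uncertain. The expected change is an at least 100-fold lower number from compound 1 to compound 3 (2.00 log units; beyond the scatter). For compound 3 the estimate is 1000 nM, with an expected range from 30 nM to 50000 nM.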

Compound 3, half-maximal inhibitory concentration: 40000 nM
Estimate against measurement, compound 3: 40-fold (1.60 log units) below, and the stated range covers the measured number.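

On the saturated ring carbon next to the ring atom that bears a hydroxy group, replacing the group with one six-membered aromatic ring with 1 hetero atom by the group with one six-membered aromatic ring with 2 hetero atoms gives a measurable change in this assay: an at least 2.5-fold lower number from compound 1 to compound 3 (0.39 log units; beyond the scatter). With compound 3 at 40000 nM, the core of compound 1 now has a measured number at this position. The value of compound 1 is a limit, so the step gives only a lower bound on the change: the limit of > 100000 nM in this assay, at which 1 of the 3 values shown sits.

The compounds shown do not tell which part of the entering group accounts for the step. As far as these compounds go, it also remains open how a carboxylic acid or a morpholine on this saturated ring carbon would read in this assay.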